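From ethoxycarbonyl to hydroxymethyl on a weak inhibitor

The source may hold more compounds than are shown below. What is called first, only, known or untested is meant among the compounds shown, and "the series" means these compounds.

Among the measured compounds shown here, in a functional assay on Maver1 cells (Homo sapiens) for inhibition, read by luminescence and CellTiter-Glo, with a stated time of 72 h (a lower number here means a stronger inhibitor, a higher number a weaker inhibitor), compound 1 `C/C=C/C(=O)N1CCCC(n2nc(-c3ccc(Oc4ccccc4)cc3)cc2C(=O)OCC)C1` gives 19600 nM, the higher of the two numbers measured so far, and compound 2 `CCOC(=O)c1cc(-c2ccc(Oc3ccccc3)cc2)nn1C1CCCN(C(=O)CCl)C1` gives 1200 nM. For the measured compounds named here, the only measured step, a 16-fold lower number from compound 1 to compound 2 (1.21 log units; beyond the scatter), is large, but it puts chloromethyl in place of prop-1-en-1-yl on a carbonyl carbon, elsewhere in the molecule. Compound 3 `C/C=C/C(=O)N1CCCC(n2nc(-c3ccc(Oc4ccccc4)cc3)cc2CO)C1` keeps that prop-1-en-1-yl group and instead has hydroxymethyl in place of ethoxycarbonyl on an aromatic carbon. Going by the values given here, no measured step covers this change, so its size and direction cannot be read from the data, and the large step sets no guide. Little net change is therefore assumed, with wide uncertainty. The expected step is a 1.3-fold lower number from compound 1 to compound 3 (0.12 log units; within the scatter). For compound 3, the estimated value is 15000 nM, within an expected range of 5000 nM to 45000 nM.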

Compound 3, half-maximal inhibitory concentration: > 60000 nM
Compound 3: only a limit was reported (the forecaster's own chance of this, stated with the estimate: 25%); middle value at least 4.0-fold (0.60 log units) from the limit.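

Ethoxycarbonyl on this aromatic carbon cannot be swapped for hydroxymethyl without a cost: in this assay, the change gives an at least 3.0-fold higher number from compound 1 to compound 3 (0.48 log units; beyond the scatter). For compound 3, > 60000 nM is a limit and not a number. The one earlier step changed only the group on the carbonyl carbon, so this is the first measured sign that the group on the aromatic carbon also matters, and the size of the step stays open at its upper end: the limit of > 60000 nM in this assay, at which 1 of the 3 values shown sits.

From the compounds shown here alone, one replacement cannot show which feature of ethoxycarbonyl counts, so it remains open whether a carboxylic acid or a primary amide on this carbon would keep the number closer to that of compound 1. Also open, going by these compounds, is whether hydroxymethyl would carry the same cost with the chloromethyl group of compound 2 on the carbonyl carbon.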